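A few compounds are considered here, and "the series" means these few. Any claim that something is new, unique, unknown or untested is made for them only; others in the source may bear on it.

Series notes. The shared core is that of compound 1 `CC1=C(/C=C/C(=O)/C=C/c2ccccc2F)C(C)(C)CCC1`; in a functional assay on LNCaP cells (Homo sapiens) for cytotoxicity, read by MTT assay, with a stated time of 72 h (on this read-out higher numbers stand for weaker inhibition and lower numbers for stronger inhibition), compound 1 gives 10700 nM. Of the three numbers in hand this stands second highest. Compound 2 `CC1=C(/C=C/C(=O)/C=C/c2ccc(O)c([N+](=O)[O-])c2)C(C)(C)CCC1` gives 26800 nM in this assay, a higher number than that of compound 1 and beyond the scatter; compound 3 `CC1=C(/C=C/C(=O)/C=C/c2cc([N+](=O)[O-])ccc2Cl)C(C)(C)CCC1` gives 4200 nM in this assay, a lower number and also beyond the scatter. For the measured compounds named here, no single-change step between measured compounds exists here. The change to compound 4 `CC1=C(/C=C/C(=O)/C=C/c2cccc(C)c2)C(C)(C)CCC1` is 3-methylphenyl in place of 2-fluorophenyl on a double-bonded chain carbon bound to a double-bonded chain carbon. Nothing measured bears on this exchange, so no step beyond the scatter is expected in either direction. Compound 4 is expected to give about 10000 nM in this assay, within 4000 nM to 25000 nM, the expected step being a 1.1-fold lower number from compound 1 to compound 4 (0.03 log units; within the scatter).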

Compound 4, half-maximal inhibitory concentration: 17800 nM
Compound 4: middle estimate off by 1.8-fold (0.25 log units), on the low side; measured number inside the range.
By their numbers in this assay, from the lowest: compound 3; then compounds 1, 4 and 2 (each within the scatter of the next, the first and the last beyond it).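

This gives the series its first single-change step: in this assay, 3-methylphenyl in place of 2-fluorophenyl on a double-bonded chain carbon bound to a double-bonded chain carbon gives a 1.7-fold higher number from compound 1 to compound 4 (0.22 log units; within the scatter), so this exchange does not separate the two compounds. This place therefore tolerates the exchange of these two substituted phenyl groups without a step beyond the scatter. No measurement available here accounts for this result. Still open, from the compounds shown here alone, is whether an aminophenyl or carboxyphenyl group at this place would give a step beyond the scatter. The fluorine and the methyl also remain unseparated, as both the group and its ring position differ in this one exchange.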